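Adding a basic amine to the side chain of compound 1

This account rests on a few compounds, and the source may have more. Where it says the series, first, only, none or still open, it means among the compounds named here.

Compound 1 `CCCCN1C(=O)NC2(CSC3=C2C(=O)c2ccccc2C3=O)C1=O` gives 178 nM in a functional assay on MCF7 cells (Homo sapiens) for inhibition (on this read-out lower numbers stand for stronger inhibition and higher numbers for weaker inhibition), the highest of the three numbers measured. Compound 2 `NCCCN1C(=O)NC2(CSC3=C2C(=O)c2ccccc2C3=O)C1=O` gives 25 nM and compound 3 `CN(C)CCN1C(=O)NC2(CSC3=C2C(=O)c2ccccc2C3=O)C1=O` gives 32 nM. The step of a 7.1-fold lower number from compound 1 to compound 2 (0.85 log units; beyond the scatter) and the step of a 5.6-fold lower number from compound 1 to compound 3 (0.75 log units; beyond the scatter) both place an amine at the end of the side chain, and the pair compound 2 and compound 3 shows a 1.3-fold higher number from compound 2 to compound 3 (0.11 log units; within the scatter). Compound 4 `CCN(CC)CCCN1C(=O)NC2(CSC3=C2C(=O)c2ccccc2C3=O)C1=O` carries the change (diethylamino in place of methyl on a saturated chain carbon, three bonds along the chain from an amide-type nitrogen in a ring). Both measured steps point the same way, so a drop of similar size is expected here, namely a 5.1-fold lower number from compound 1 to compound 4 (0.71 log units; beyond the scatter). Compound 4 is therefore estimated at 35 nM, with a likely range from 15 nM to 85 nM.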

Compound 4, half-maximal inhibitory concentration: 26 nM
Compound 4: the middle estimate sits 1.3-fold (0.13 log units) above what was measured; the range from low to high includes it.
By their numbers in this assay, from the lowest: compounds 2, 4 and 3 (each within the scatter of the next); then compound 1.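

The drop in the number holds with diethylamino at the end of the chain, a much bulkier amine by count of atoms (a 6.8-fold lower number from compound 1 to compound 4 (0.84 log units; beyond the scatter)). In this assay, the four added carbons of diethylamino leave it within the scatter of both smaller amines (a 1.2-fold lower number from compound 3 to compound 4 (0.09 log units; within the scatter); a 1.0-fold higher number from compound 2 to compound 4 (0.02 log units; within the scatter)), so amino, dimethylamino and diethylamino cannot be told apart on these numbers. Nothing available explains why these three amines give such similar numbers.

Open, on these data alone, is whether a carboxylic acid at the chain end would give a similar number. Also open, as far as these compounds go, is how a piperidine ring or a longer chain carrying the amine would compare.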